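The compounds below may be only part of what the source reports. "The series", "measured", "known", "first", "only" and "open" are said of these compounds alone.

Measured so far in an ADME assay on HepG2 cells (Homo sapiens) for cytotoxicity, read by MTT assay, with a stated time of 72 h; on this read-out lower numbers stand for higher toxicity in this test and higher numbers for lower toxicity in this test:
Compound 1 `O=[N+]([O-])c1c(CS(=O)(=O)c2ccccc2)nc2c(-c3ccccc3F)cc(Cl)cn12`: > 3900 nM, a limit
Compound 2 `O=[N+]([O-])c1c(CS(=O)(=O)c2ccccc2)nc2c(-c3cccc(C(F)(F)F)c3)cc(Cl)cn12`: > 12500 nM, a limit

Compound 2 has no exact position in this assay. Its reading of > 12500 nM is a limit and not a number. Compound 1 is also known only by a limit, > 3900 nM.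

Compound 3 `O=[N+]([O-])c1c(CS(=O)(=O)c2ccccc2)nc2c(-c3ccccc3C(F)(F)F)cc(Cl)cn12` has the same atoms as compound 2, joined differently: 2-(trifluoromethyl)phenyl in place of 3-(trifluoromethyl)phenyl on an aromatic carbon. A 2-(trifluoromethyl)phenyl stands in place of 3-(trifluoromethyl)phenyl on an aromatic carbon.

Within the data shown here, only one measured step bears on this change, a step that the two limits leave unreadable from compound 1 to compound 2. It has no readable size, so it gives no measure of what a change at this place can do, and no direction can be drawn from it. The expectation therefore rests on compound 2, with its limit of > 12500 nM. The expected change is a number no higher from compound 2 to compound 3 (the limit leaves the size open), which means no step beyond the usual scatter. For compound 3 the estimated value is 12500 nM, with an expected range from 4000 nM to 40000 nM, and the assay may well report only a limit again.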

Compound 3, half-maximal cytotoxic concentration: 22700 nM
Beside the measured number, compound 3's estimate is 1.8-fold (0.26 log units) below it; the measured number falls inside the stated range.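

In this assay the steps to compound 3 from compound 2 and from compound 1 cannot be read: those two compounds are known only as limits, and compound 3 alone carries a number. The compounds shown leave open whether 2-(trifluoromethyl)phenyl in place of 3-(trifluoromethyl)phenyl, or trifluoromethyl in place of fluoro, changes this read-out at all.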